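The compounds below may be only part of what the source reports. "The series", "measured", "known", "first", "only" and "open" are said of these compounds alone.

Compound 3 `Cc1ccc(N2CCN(C(=O)[C@@H]3CN(C4CCOCC4)C[C@H]3c3ccc(Cl)cc3)CC2)c([C@@H](NC(=O)CN)C(C)C)c1` gives the highest of the three numbers measured in a functional assay on CHO cells with Melanocortin receptor 4 (Homo sapiens) as the target, read by cAMP accumulation; on this read-out higher numbers stand for larger maximal responses and lower numbers for smaller maximal responses: compound 3 gives 114%. Its nearest neighbour is compound 2 `Cc1ccc(N2CCN(C(=O)[C@@H]3CN(C4CCOCC4)C[C@H]3c3ccc(Cl)cc3)CC2)c([C@@H](NC(=O)CCN)C(C)C)c1`, which in this assay gives 107%, and the step between them, a number 7 percentage points higher from compound 2 to compound 3 (within the scatter), lies within the scatter. Furthest away is compound 1 `Cc1ccc(N2CCN(C(=O)[C@@H]3CN(C4CCOCC4)C[C@H]3c3ccc(Cl)cc3)CC2)c([C@@H](NC(=O)[C@@H](C)N)C(C)C)c1`, which in this assay gives 56%; the steps of a number 58 percentage points higher from compound 1 to compound 3 (beyond the scatter) and a number 51 percentage points higher from compound 1 to compound 2 (beyond the scatter) are both large and beyond the scatter.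

Compound 4 `CNCC(=O)N[C@H](c1cc(C)ccc1N1CCN(C(=O)[C@@H]2CN(C3CCOCC3)C[C@H]2c2ccc(Cl)cc2)CC1)C(C)C` differs from compound 3 in one place: methyl in place of hydrogen on an amine nitrogen. Among the compounds with values here, none of the measured steps touches the amine nitrogen; they concern the carbon chain between the amine nitrogen and the carbonyl carbon, so no measured step bears directly on this change. The two compounds with an unsubstituted aminomethyl or aminoethyl chain, compound 2 and compound 3, both sit near the reference agonist's maximum, and the new group carries no donor or acceptor of its own. The step of a number 9 percentage points lower from compound 3 to compound 4 (within the scatter) is therefore expected to remain within the scatter. Compound 4 is estimated at 105%, with a range from 80% to 125%.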

Compound 4, intrinsic activity: the largest response reached, in percent of the reference agonist's: 84%
Compound 4: the middle estimate sits 21 percentage points above what was measured; low and high end bracket the measured number.
By their numbers in this assay, from the lowest: compound 1; then compound 4; then compounds 2 and 3 (each within the scatter of the next).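

Methyl in place of hydrogen on the amine nitrogen is the first change shown at the nitrogen itself, and in this assay it gives a number 30 percentage points lower from compound 3 to compound 4 (beyond the scatter), so this nitrogen does not tolerate even this one added carbon without a change in maximal response. Compound 4 also stands apart from the other two chains, with a number 23 percentage points lower from compound 2 to compound 4 (beyond the scatter) and a number 28 percentage points higher from compound 1 to compound 4 (beyond the scatter), which places it in the middle of the series rather than with either group of compounds. Nothing given here explains these steps.

On these data alone, whether an ethyl group on the same nitrogen, or a second methyl making a dimethylamino group, would take the response lower remains open. So does the effect of the same methyl on the nitrogen of the 1-aminoethyl chain.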